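Fused diamine series: amine linker in place of ether

The compounds below may be only part of what the source reports. "The series", "measured", "known", "first", "only" and "open" are said of these compounds alone.

Three compounds of a shared core have numbers in a functional assay on NCI-H23 cells (Homo sapiens) for inhibition, read by sulforhodamine B assay, with a stated time of 48 h; a lower number here means a stronger inhibitor of growth, a higher number a weaker inhibitor of growth. Compound 1 `Nc1cc(N)c2nc(-c3ccccc3)c(Oc3ccc(F)cc3)nc2c1` gives 39800 nM, the highest of the three. Compound 3 `CCOC(=O)[C@H](CCC(=O)O)NC(=O)c1ccc(Oc2nc3cc(N)cc(N)c3nc2-c2ccccc2)cc1` gives 30200 nM, which lies within the scatter of compound 1. Compound 2 `COc1cc(CNc2nc3cc(N)cc(N)c3nc2-c2ccccc2)cc(OC)c1OC` gives 17000 nM, beyond the scatter below compound 1. Among the measured compounds shown here, with so few points, no steps between single-change pairs exist, and no pattern is claimed.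

Compound 4 `Nc1cc(N)c2nc(-c3ccccc3)c(NCc3ccc(F)cc3)nc2c1` is not yet measured. It differs from compound 1 in one place:

(4-fluorobenzyl)amino in place of 4-fluorophenoxy on an aromatic carbon

The substituent sits on an aromatic carbon next to the ring nitrogen, ortho to a phenyl group. The ether oxygen gives way to an amine bearing one hydrogen-bond donor, the 4-fluorophenyl part being retained with one added carbon.

A moderate step toward a lower number, a 2.0-fold lower number from compound 1 to compound 4 (0.30 log units; within the scatter), is expected from compound 1 to compound 4, because compound 2 gives 17000 nM with an amine-linked substituent on the same core. Compound 4 is accordingly estimated at 20000 nM, with a range from 8000 nM to 50000 nM; the data supporting this are thin.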

Compound 4, concentration for total growth inhibition: 4570 nM
Compound 4: middle estimate off by 4.4-fold (0.64 log units), on the high side, outside the stated range (below it).
By their numbers in this assay, from the lowest: compound 4; then compounds 2, 3 and 1 (each within the scatter of the next, the first and the last beyond it).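

In this assay, among the compounds shown here, this position on an aromatic carbon of the shared core proves sensitive to the linker: (4-fluorobenzyl)amino in place of 4-fluorophenoxy gives an 8.7-fold lower number from compound 1 to compound 4 (0.94 log units; beyond the scatter) and so provides the first single-change step, one that lies beyond the scatter. The 4-fluorophenyl part is present in both compounds, so the step belongs to the link that joins it to the core, where an amine with a hydrogen-bond donor and a longer connection replace the ether oxygen together. Nothing shown explains the step.

For the compounds shown here, the single pair leaves open whether the amine or the longer connection accounts for the step. A (4-fluorophenyl)amino group, with the amine but not the longer connection, and a 4-fluorobenzyloxy group, with the longer connection but not the amine, would separate the two.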